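The compounds below may be only part of what the source reports. "The series", "measured", "known", "first", "only" and "open" are said of these compounds alone.

Working notes on the series. Within the data shown here, compound 2 `CN(C)CCCCCSC1=Nc2ccccc2C(CC(=O)NCc2ccc(F)cc2)N1c1ccc(-c2ccccc2)cc1` stands lowest of the two numbers so far: in a functional assay on A549 cells (Homo sapiens) for cytotoxicity, read by MTT assay, with a stated time of 48 h (a lower number here means a stronger inhibitor, a higher number a weaker inhibitor), compound 2 gives 5000 nM, while compound 1 `CN(C)CCCCCSC1=Nc2ccccc2C(CC(=O)NCc2ccccc2)N1c1ccc(-c2ccc(F)cc2)cc1` gives 17600 nM in this assay, a gap beyond the scatter. Compound 3 `CN(C)CCCCCSC1=Nc2ccccc2C(CC(=O)NCc2ccc(F)cc2)N1c1ccc(-c2ccc(F)cc2)cc1` differs from compound 2 by fluoro in place of hydrogen on an aromatic carbon. Among the measured compounds shown here, no single-change step is on record for this substitution, and compound 1 carries the same fluorophenyl with a weaker number. Compound 3 is therefore expected to give a step of a 1.6-fold higher number from compound 2 to compound 3 (0.20 log units; within the scatter) toward a somewhat higher number. Compound 3 is estimated at 8000 nM in this assay, within 3000 nM to 25000 nM.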

Compound 3, half-maximal inhibitory concentration: 11300 nM
Beside the measured number, compound 3's estimate is 1.4-fold (0.15 log units) below it; the measured number falls inside the stated range.
By their numbers in this assay, from the lowest: compound 2; then compounds 3 and 1 (each within the scatter of the next).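

In this assay, phenyl to 4-fluorophenyl now has its first single-change readings: a 2.3-fold higher number from compound 2 to compound 3 (0.35 log units; beyond the scatter) is a modest step beyond the scatter, whereas the fluoro entering the other phenyl, a 1.6-fold lower number from compound 1 to compound 3 (0.19 log units; within the scatter), stays within it. The same substitution therefore does not read alike at the two places, and neither fluoro step gives a gain over compound 2. Nothing on hand bears on the reason for this.

Open, going by these compounds, is whether chloro or methoxy at these places would read like fluoro. Also open, on these data alone, is how a morpholine or a primary amine in place of the dimethylamino group would read.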